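Bringing a Sulfonamide Arm Back onto the Shared Core

The source may hold more compounds than are shown below. What is called first, only, known or untested is meant among the compounds shown, and "the series" means these compounds.

Of the compounds shown here, three built on one shared core have been tested in a functional assay on SW-620 cells (Homo sapiens) for antiproliferative activity, read by MTT assay, with a stated time of 72 h; a higher number here means a weaker inhibitor, a lower number a stronger inhibitor. Compound 1 `Cc1ccc(S(=O)(=O)NCc2cn(C[C@H](O)[C@H]3OC(=O)C(OCc4ccccc4)=C3OCc3ccccc3)nn2)cc1` carries a (((4-methylphenyl)sulfonyl)amino)methyl group on an aromatic carbon, and compound 1 gives 45800 nM. Compound 2 `O=C1O[C@H]([C@@H](O)Cn2cc(-c3cc(F)cc(F)c3)nn2)C(OCc2ccccc2)=C1OCc1ccccc1` carries a 3,5-difluorophenyl there; for compound 2 the assay reports only a limit, > 100000 nM. Compound 3 `COc1ccccc1-c1cn(C[C@H](O)[C@H]2OC(=O)C(OCc3ccccc3)=C2OCc2ccccc2)nn1` carries a 2-methoxyphenyl; for compound 3 too the result is only a limit, > 100000 nM. Compound 3 thus sits at the weak end of what is shown, alongside compound 2, because of the limit of > 100000 nM in this assay, at which 2 of the 3 values shown sit. The steps of an at least 2.1-fold higher number from compound 1 to compound 2 (0.33 log units; beyond the scatter) and an at least 2.1-fold higher number from compound 1 to compound 3 (0.33 log units; beyond the scatter) run the same way, while a step that the two limits leave unreadable from compound 2 to compound 3 cannot be sized.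

Compound 4 `O=C1O[C@H]([C@@H](O)Cn2cc(CNS(=O)(=O)c3ccc(Cl)cc3)nn2)C(OCc2ccccc2)=C1OCc1ccccc1` differs from compound 3 by (((4-chlorophenyl)sulfonyl)amino)methyl in place of 2-methoxyphenyl on an aromatic carbon. Going by the values given here, this restores a sulfonamide arm close to that of compound 1, whose 45800 nM is the only value here that is not a limit, and the steps of an at least 2.1-fold higher number from compound 1 to compound 2 (0.33 log units; beyond the scatter) and an at least 2.1-fold higher number from compound 1 to compound 3 (0.33 log units; beyond the scatter) show that losing such an arm weakened inhibition. Compound 4 is therefore expected to give about 45000 nM, between 15000 nM and 150000 nM. The expected step of an at least 2.2-fold lower number from compound 3 to compound 4 (0.34 log units; beyond the scatter) would be a move toward a stronger inhibitor, though a second limit cannot be excluded.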

Compound 4, half-maximal inhibitory concentration: 18000 nM
Estimate against measurement, compound 4: 2.5-fold (0.40 log units) above; the measured number falls inside the stated range.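

Two sulfonamide arms now stand ahead of two aryl groups on this aromatic carbon, with an at least 5.5-fold lower number from compound 3 to compound 4 (0.74 log units; beyond the scatter) and an at least 5.5-fold lower number from compound 2 to compound 4 (0.74 log units; beyond the scatter), so the advantage no longer rests on compound 1 alone. Going by these compounds alone, the far end of the arm also counts: chloro in place of methyl gives a 2.5-fold lower number from compound 1 to compound 4 (0.41 log units; beyond the scatter), the first step with an exact size rather than a bound. The two steps from the aryl compounds give only minimum sizes because compound 2 and compound 3 are both limits: the limit of > 100000 nM in this assay, at which 2 of the 4 values shown sit.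

On these data alone, it remains open whether an amide in place of the sulfonamide, or a longer chain linking it to the five-membered aromatic ring, would keep this gain. As far as these compounds go, it is also open whether a trifluoromethyl group in place of the chloro would strengthen inhibition further.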